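The source may report more compounds than this note shows. Statements on the series, on what has been measured and on what is new or still open speak of the compounds shown alone.

The measured compounds so far:

Compound 1 `COCCOc1cc2c(-n3nc(-c4ccccn4)nc3N)ncnc2cc1OC`: in an assay on MCF7 cells for inhibition of Serine-protein kinase ATM (Homo sapiens), read by immunofluorescence, with a stated time of 1 h (a lower number here means a stronger inhibitor, a higher number a weaker inhibitor), compound 1 gives 1200 nM.
Compound 2 `COc1cc2ncnc(-n3nc(-c4ccccn4)nc3N)c2cc1OCCCNC(=O)OC(C)(C)C`: in this assay compound 2 gives 900 nM.

Compound 2 has the lower of the two numbers, but the gap to compound 1 is small: the step of a 1.3-fold lower number from compound 1 to compound 2 (0.12 log units; within the scatter) lies within the scatter, so the two values cannot be told apart. Within the data shown here, the one change seen so far, ((tert-butoxycarbonyl)amino)methyl in place of methoxy on a saturated chain carbon, therefore left the read-out essentially where it was.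

Compound 3 `CCOC(=O)NCCCOc1cc2c(-n3nc(-c4ccccn4)nc3N)ncnc2cc1OC` differs from compound 2 by ethyl in place of tert-butyl on an oxygen next to a carbonyl group. Among the measured compounds shown here, no measured step touches this part of the molecule; the only comparison available, from compound 1 to compound 2, changed a different part of the same chain and stayed within the scatter. With nothing pointing either way, a step of no real size is expected in this assay. Compound 3 is expected to give about 900 nM, in a range from 400 nM to 2000 nM. The expected step of no change at the digits printed from compound 2 to compound 3 (within the scatter) should stay within the scatter.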

Compound 3, half-maximal inhibitory concentration: 800 nM
Estimate against measurement, compound 3: 1.1-fold (0.05 log units) above, within the range that was stated.
By their numbers in this assay, from the lowest: compounds 3, 2 and 1 (each within the scatter of the next).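

In this assay, replacing tert-butyl (4 heavy atoms) with ethyl (2 heavy atoms) on an oxygen next to a carbonyl group gives a 1.1-fold lower number from compound 2 to compound 3 (0.05 log units; within the scatter) and so does not separate these two groups. Compound 3 also gives the second comparison with the methoxy side chain of compound 1, with ((ethoxycarbonyl)amino)methyl in place of methoxy on a saturated chain carbon, and this reads a 1.5-fold lower number from compound 1 to compound 3 (0.18 log units; within the scatter) so neither of the two groups ending in a carbonyl-linked oxygen can be told apart from methoxy at this place. Nothing measured alongside these numbers offers an explanation for them.

The compounds shown leave open whether a free amine in place of the (ethoxycarbonyl)amino group, or a carboxylic acid at the end of the chain, would move the number beyond the scatter. They also leave open whether a phenyl ring on the oxygen next to a carbonyl group, or a longer chain between the shared core and that group, would give a step of real size.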